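This account rests on a few compounds, and the source may have more. Where it says the series, first, only, none or still open, it means among the compounds named here.

Measured compounds in a functional assay on the whole organism with Rattus norvegicus as the target; a lower number here means that less compound is needed, a higher number that more compound is needed for the effect:
- compound 1 `CCN(CCNC(=O)c1cc(Cl)c(N)cc1OC)Cc1ccccc1` with 0.31 mg/kg as its value
- compound 2 `CCNCCNC(=O)c1cc(Cl)c(N)cc1OC` with > 30 mg/kg as a limit
- compound 3 `CCN(CCNC(=O)c1cc(Cl)c(N)cc1OC)Cc1cccc(Cl)c1` with 0.58 mg/kg as its value

Compound 1 shares the low end of these numbers with compound 3, the gap being a 1.9-fold higher number from compound 1 to compound 3 (0.27 log units; within the scatter) and no real separation. Compound 4 `COc1cc(N)c(Cl)cc1C(=O)NCCN(Cc1ccccc1)C(C)(C)C` differs from compound 1 at one place, tert-butyl in place of ethyl on an amine nitrogen, counted as tert-butyl in place of ethyl on an amine nitrogen with the rest unchanged.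

Going by the values given here, no measured step touches the ethyl group itself. The closest guide is an at least 96-fold higher number from compound 1 to compound 2 (1.98 log units; beyond the scatter) at the same nitrogen, matched by an at least 51-fold lower number from compound 2 to compound 3 (1.71 log units; beyond the scatter) in the opposite direction. Both show that a change on this nitrogen can move this assay a long way in these compounds, though both concern benzyl, which compound 4 keeps. A moderate rise in the number is therefore expected, well short of those large steps. The expected change is an 8.1-fold higher number from compound 1 to compound 4 (0.91 log units; beyond the scatter) on this reasoning. Compound 4 is estimated at 2.5 mg/kg with an expected range from 0.4 mg/kg to 20 mg/kg in all.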

Compound 4, dose for half-maximal effect: > 30 mg/kg
Compound 4 ended at the assay's limit; the forecaster's own chance of this, stated with the estimate: 20%; at least 12-fold (1.07 log units) between middle value and limit.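

The earlier steps shown here on this amine nitrogen all concerned benzyl; here, with benzyl kept, tert-butyl in place of ethyl gives an at least 96-fold higher number from compound 1 to compound 4 (1.98 log units; beyond the scatter) in this assay. Compound 4 gives > 30 mg/kg, which is a limit of the assay and not a number, so this step has a known minimum but no known full size. The group that stays beside benzyl on this nitrogen can therefore take a compound to the same limit as removing benzyl does: the limit of > 30 mg/kg in this assay, at which 2 of the 4 values shown sit.

What the compounds shown leave open is whether methyl, isopropyl or a longer chain in place of ethyl would keep the number close to that of compound 1 or also reach the limit. They also leave open how far the true dose of compound 4 lies past that limit.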